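Sulfur-linked side chains on the shared core: toward compound 4

The source may hold more compounds than are shown below. What is called first, only, known or untested is meant among the compounds shown, and "the series" means these compounds.

Measured so far in an assay on isolated protein for inhibition of Norepinephrine transporter (Rattus norvegicus), read by radioligand binding; on this read-out higher numbers stand for weaker inhibition and lower numbers for stronger inhibition:
- compound 1, `COCCSCC1CN(C)CCC1c1ccc(Cl)cc1`, 6 nM
- compound 2, `COCC[S+]([O-])CC1CN(C)CCC1c1ccc(Cl)cc1`, 25 nM
- compound 3, `CC(=O)OCCSCC1CN(C)CCC1c1ccc(Cl)cc1`, 3.6 nM

Compound 3 gives the lowest number of the three, though its gap to compound 1 is within the scatter (a 1.7-fold lower number from compound 1 to compound 3 (0.22 log units; within the scatter)); only compound 2 stands clearly apart (a 6.9-fold lower number from compound 2 to compound 3 (0.84 log units; beyond the scatter)).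

Compound 4, `CN1CCC(c2ccc(Cl)cc2)C(C[S+]([O-])CC(=O)NO)C1`, is not yet measured. Relative to compound 3 the change is a group of 7 heavy atoms (2 carbon, 1 nitrogen, 3 oxygen, 1 sulfur; no ring) in place of a group of 7 heavy atoms (4 carbon, 2 oxygen, 1 sulfur; no ring), on a saturated chain carbon bound to a saturated ring carbon. Among the compounds with values here, two measured steps touch the same place. The step of a 4.2-fold higher number from compound 1 to compound 2 (0.62 log units; beyond the scatter) shows that altering the sulfur-bearing chain on this position can cost a modest amount, and the entering group of compound 4 shares that feature of the chain of compound 2. The step of a 1.7-fold lower number from compound 1 to compound 3 (0.22 log units; within the scatter) shows that the far end of the chain tolerates exchange without a shift beyond the scatter. Within the data shown here, no measured compound carries hydrogen-bond donors on this chain, so that part of the change is uncharted.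

The expectation for compound 4 is therefore a modest rise in this assay, a 14-fold higher number from compound 3 to compound 4 (1.14 log units; beyond the scatter), with a wide range. Compound 4 is estimated at 50 nM, between 12 nM and 250 nM.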

Compound 4, inhibition constant: 12 nM
Beside the measured number, compound 4's estimate is 4.2-fold (0.62 log units) above it; low and high end bracket the measured number.
By their numbers in this assay, from the lowest: compounds 3, 1 and 4 (each within the scatter of the next, the first and the last beyond it); then compound 2.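

Hydrogen-bond donors on the chain at this place, on a saturated chain carbon bound to a saturated ring carbon, prove compatible with binding in this assay: the entering group of compound 4 gives a 2.0-fold higher number from compound 1 to compound 4 (0.30 log units; within the scatter), a step within the scatter. The cost seen with compound 2 is not fixed for chains that share its oxygen on sulfur, since hydroxycarbamoyl in place of methoxymethyl gives a 2.1-fold lower number from compound 2 to compound 4 (0.32 log units; beyond the scatter), although the exchange for (2-acetoxyethyl)sulfanyl still leaves a 3.3-fold higher number from compound 3 to compound 4 (0.52 log units; beyond the scatter). No measurement here offers an explanation for these shifts.

Still open, on these data alone, is how hydroxycarbamoyl would read on a chain without the oxygen on sulfur, which would separate the two parts of the change. Also open, as far as these compounds go, is whether a carboxylic acid, an amine or a longer chain at the same end would keep the number of compound 4.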